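The source may report more compounds than this note shows. Statements on the series, on what has been measured and on what is new or still open speak of the compounds shown alone.

Compound 1 `O=C(Nc1cccc(CN2CCCC2)c1)C1CCCN(C(=O)c2cc(C(F)(F)F)cc(C(F)(F)F)c2)C1` is the most cytotoxic of the three measured compounds. In an ADME assay on PC-3 cells (Homo sapiens) for cytotoxicity, read by WST assay, tested at 100 uM (on this read-out lower numbers stand for less inhibition and higher numbers for more inhibition at the one concentration tested (going by the name of the read-out)), compound 1 gives 51%, the highest value among them; the distance to the other two is beyond the scatter. Compound 2 `O=C(Nc1cccc(Oc2ccccc2)c1)C1CCCN(C(=O)c2cccc(-c3ccco3)c2)C1` gives 0% in this assay, and compound 3 `Cc1nc(-c2cccc(C(=O)N3CCCC(C(=O)Nc4ccc(Cl)cc4)C3)c2)no1` gives 0%. Both of these differ from compound 1 in several places, so only their values can be set beside its own.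

Compound 4 `COc1cccc(NC(=O)C2CCCN(C(=O)c3cc(C(F)(F)F)cc(C(F)(F)F)c3)C2)c1` is the next compound to be measured. It follows from compound 1 by a single change: methoxy in place of (pyrrolidin-1-yl)methyl on an aromatic carbon. Among the measured compounds shown here, the group that leaves brings a five-membered non-aromatic ring with it; the methoxy that enters is far smaller, and no measured pair shows the effect of this exact change.

The expected step from compound 1 to compound 4 is a number 36 percentage points lower from compound 1 to compound 4 (beyond the scatter), downward, since the two measured compounds without the (pyrrolidin-1-yl)methyl group both sit at the bottom of the scale. Compound 4 is therefore estimated at 15%, within a range from 0% to 45%.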

Compound 4, a percentage reported as inhibition, at one concentration (the size of the read-out at that concentration, not a potency): 0%
For compound 4 the middle estimate is 15 percentage points above the measured one; the measured number falls inside the stated range.
By their numbers in this assay, from the lowest: compounds 2, 3 and 4 (each within the scatter of the next); then compound 1.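

In this assay, among the compounds shown here, methoxy in place of (pyrrolidin-1-yl)methyl on this aromatic carbon gives a number 51 percentage points lower from compound 1 to compound 4 (beyond the scatter), the first step at this position that can be read. All else in compound 1 is kept, so that part of the structure alone does not carry the inhibition: with methoxy at this position, compound 4 gives 0%. The inhibition of compound 1 therefore depends on what sits at this one position, although nothing shown explains why the step is so large.

On these data alone, it remains open whether a smaller amine such as dimethylaminomethyl, or a ring without nitrogen such as cyclopentylmethyl, would keep any of the inhibition here. As far as these compounds go, it is equally open whether (pyrrolidin-1-yl)methyl has the same effect when the other end of the molecule is changed.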